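Chloro in Place of Trifluoromethyl on Two Cores

A few compounds are considered here, and "the series" means these few. Any claim that something is new, unique, unknown or untested is made for them only; others in the source may bear on it.

Of the compounds shown here, three have been measured in a functional assay on HL-60 cells (Homo sapiens) for cytotoxicity, read by luminescence and CellTiter-Glo, with a stated time of 3 days; a lower number here means a stronger inhibitor, a higher number a weaker inhibitor. Compound 1 `N#Cc1ccc(NC(=O)c2ccc(Cl)cc2O)cc1` gives 1300 nM, compound 2 `N#Cc1ccc(NC(=O)c2ccc(C(F)(F)F)cc2O)cc1` gives 1030 nM, and compound 3 `O=C(Nc1ccc(C(F)(F)F)cc1)c1ccc2cccnc2c1O` gives 680 nM. Compounds 1 and 2 share one core and differ by chloro in place of trifluoromethyl on an aromatic carbon; that change gave a 1.3-fold higher number from compound 2 to compound 1 (0.10 log units; within the scatter). Compound 3 rests on another core; the difference between the two cores is not broken down here, and its value sits within the scatter of those of compounds 1 and 2.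

Compound 4 `O=C(Nc1ccc(Cl)cc1)c1ccc2cccnc2c1O` has not yet been measured. It differs from compound 3 by chloro in place of trifluoromethyl on an aromatic carbon. Among the compounds with values here, this is the same kind of change as the one between compounds 2 and 1, though the surroundings are not identical: in compounds 1 and 2 the carbon carrying the group is also meta to a hydroxy group (1 heavy atom), whereas in compounds 3 and 4 only the placing para to a large group is shared. Because the earlier change gave a 1.3-fold higher number from compound 2 to compound 1 (0.10 log units; within the scatter), a similarly small step is expected here. The expected step is a 1.3-fold higher number from compound 3 to compound 4 (0.10 log units; within the scatter). For compound 4 in this assay the estimate is 850 nM, between 350 nM and 2000 nM.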

Compound 4, half-maximal inhibitory concentration: 630 nM
For compound 4 the middle estimate is 1.3-fold (0.13 log units) above the measured one; measured number inside the range.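

In this assay, putting chloro in place of trifluoromethyl on the core of compound 3 gave a 1.1-fold lower number from compound 3 to compound 4 (0.03 log units; within the scatter). Set beside the same change on the core of compound 1, the two results agree as closely as such measurements allow: the same change on two cores in this assay, a 1.3-fold higher number (0.10 log units; within the scatter) from compound 2 to compound 1 and a 1.1-fold lower number (0.03 log units; within the scatter) from compound 3 to compound 4, 1.4-fold (0.13 log units) apart, within the scatter of two such steps So, in these two pairs, the swap carries from one core to the other as a step too small to tell apart from the ordinary variation between repeated measurements, but this does not prove that the two groups are truly equal in this test, and two pairs cannot establish a rule for any further core.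

The compounds shown hold only trifluoromethyl or chloro on that aromatic carbon, so they leave open what an amine, a carboxylic acid or a longer chain there would give. They also leave open whether the two cores themselves differ, as compounds 1 and 2 and compounds 3 and 4 are not linked by any single change.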